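Naphthyl in Place of Methyl on a Ring Amide Nitrogen

The source may hold more compounds than are shown below. What is called first, only, known or untested is meant among the compounds shown, and "the series" means these compounds.

Compound 1 `CC(C)[C@@H]1CC[C@@H](C)C[C@@]12N(C)C(=O)[C@@H]1[C@H]3C(=O)N(C)C(=O)[C@H]3ON12` heads a short series. In a functional assay, read by spectrophotometry, with a stated time of 2 h (a higher number here means a weaker inhibitor, a lower number a stronger inhibitor), compound 1 gives 2160 ug/mL, the highest of the two numbers measured. Going by the values given here, compound 2 `CC(C)[C@@H]1CC[C@@H](C)C[C@@]12N(C)C(=O)[C@@H]1[C@H]3C(=O)N(c4ccc(Cl)cc4)C(=O)[C@H]3ON12` gives 710 ug/mL, and the step of a 3.0-fold lower number from compound 1 to compound 2 (0.48 log units; beyond the scatter) is the only measured change that bears on the question. Compound 3 `CC(C)[C@@H]1CC[C@@H](C)C[C@@]12N(C)C(=O)[C@@H]1[C@H]3C(=O)N(c4ccc5ccccc5c4)C(=O)[C@H]3ON12` differs from compound 1 by naphthalen-2-yl in place of methyl on an amide-type nitrogen in a ring, again an aromatic group replacing methyl on the same nitrogen. The account therefore expects a step of comparable size and the same direction, a 3.6-fold lower number from compound 1 to compound 3 (0.56 log units; beyond the scatter). Compound 3 is estimated to give 600 ug/mL, within a range of 250 ug/mL to 1500 ug/mL.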

Compound 3, half-maximal inhibitory concentration: 2680 ug/mL
Estimate against measurement, compound 3: 4.5-fold (0.65 log units) below, outside the stated range (above it).
By their numbers in this assay, from the lowest: compound 2; then compounds 1 and 3 (each within the scatter of the next).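

In this assay the step of a 1.2-fold higher number from compound 1 to compound 3 (0.09 log units; within the scatter) shows that an aromatic group in place of methyl on this amide-type nitrogen in a ring does not by itself lower the number. The step of a 3.8-fold higher number from compound 2 to compound 3 (0.58 log units; beyond the scatter) separates the two aromatic groups, so the lower number of compound 2 goes with 4-chlorophenyl and not with aromatic replacement in general. Nothing available here explains that difference.

On these data alone, how a plain phenyl or a benzyl group on this nitrogen would stand against compound 2 and compound 3 remains open. So does whether the chlorine of compound 2 is needed for its lower number.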